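The compounds below may be only part of what the source reports. "The series", "measured", "known", "first", "only" and "open" are said of these compounds alone.

Of the compounds shown here, three sharing one core have been tested in a functional assay on HepG2 cells (Homo sapiens) for antiproliferative activity, read by MTT assay, with a stated time of 24 h; a higher number here means a weaker inhibitor, a lower number a stronger inhibitor. Compound 1 `O=c1[nH]cc(S(=O)(=O)Nc2ccccc2-c2cn(-c3cccc(Cl)c3)nn2)c(=O)[nH]1` gives 2460 nM, compound 2 `O=c1[nH]cc(S(=O)(=O)Nc2cccc(-c3cn(-c4cccc(Cl)c4)nn3)c2)c(=O)[nH]1` gives 4200 nM, and compound 3 `O=c1[nH]cc(S(=O)(=O)Nc2ccc(-c3cn(-c4ccccc4)nn3)cc2)c(=O)[nH]1` gives 18000 nM. Compound 3 therefore stands highest of the three numbers, and both gaps, to compound 2 and to compound 1, lie beyond the usual scatter of this assay, so compound 3 is the weakest inhibitor of the set.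

The next compound, compound 4 `Cc1ccc(-n2cc(-c3ccc(NS(=O)(=O)c4c[nH]c(=O)[nH]c4=O)cc3)nn2)cc1`, differs from compound 3 in a single place: methyl in place of hydrogen on an aromatic carbon. Within the data shown here, a methyl entering on an aromatic carbon, para to a large group, is one of the smallest changes a structure can take, and no measured pair here shows what such a change does. With nothing to build on, a step in this assay from compound 3 to compound 4 of no more than the ordinary scatter is expected, in either direction. The estimated step is a 1.2-fold lower number from compound 3 to compound 4 (0.08 log units; within the scatter). Compound 4 is expected to give about 15000 nM, within a range from 6000 nM to 40000 nM.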

Compound 4, half-maximal inhibitory concentration: 11600 nM
The estimate for compound 4 lay 1.3-fold (0.11 log units) above the measured number, and the stated range covers the measured number.
By their numbers in this assay, from the lowest: compounds 1 and 2 (each within the scatter of the next); then compounds 4 and 3 (each within the scatter of the next).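

In this assay, the change from phenyl to 4-methylphenyl gives a 1.6-fold lower number from compound 3 to compound 4 (0.19 log units; within the scatter). Among these compounds, this is the first measured pair differing in one place, and it shows that adding methyl at this position, on an aromatic carbon para to a large group, produces no difference that can be told from ordinary assay variation. A single pair cannot show whether the same would hold on another core, and no supporting measurement bears on this result.

From the compounds shown here alone, it remains open whether an amine, a carboxylic acid or a longer chain such as propyl at this same place would shift the number beyond the scatter. Going by these compounds, it also remains open whether methyl on another carbon of this ring would behave as it does here.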